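From Pyridin-4-yl to Benzyl on the Ring Nitrogen

The source may report more compounds than this note shows. Statements on the series, on what has been measured and on what is new or still open speak of the compounds shown alone.

Compound 3 `Nc1ccccc1NC(=O)c1ccc(CSC(=S)N2CCN(c3ccncc3)CC2)cc1` stands highest of the three compounds measured in a functional assay on HeLa cells (Homo sapiens) for antiproliferative activity, read by CCK-8 assay, with a stated time of 72 h, tested at 8 uM (on this read-out lower numbers stand for a weaker effect and higher numbers for a stronger effect at the one concentration tested), where compound 3 gives 77.4%; compound 1 `COc1ccc(N2CCN(C(=S)SCc3ccc(C(=O)Nc4ccccc4N)cc3)CC2)cc1` gives 52.3% and compound 2 `Cc1ccc(N2CCN(C(=S)SCc3ccc(C(=O)Nc4ccccc4N)cc3)CC2)cc1` gives 24%. Compound 4 `Nc1ccccc1NC(=O)c1ccc(CSC(=S)N2CCN(Cc3ccccc3)CC2)cc1` has not been measured; its change from compound 3 is benzyl in place of pyridin-4-yl on an amine nitrogen in a ring. Going by the values given here, two measured steps touch the same ring nitrogen: a number 25.1 percentage points higher from compound 1 to compound 3 (beyond the scatter) and a number 53.4 percentage points higher from compound 2 to compound 3 (beyond the scatter). Both put pyridin-4-yl in for a group carrying one six-membered aromatic ring of carbon only, and both raised the number. Going the other way, to benzyl, a fall of a size between those two steps is therefore expected. Compound 4 is expected to give 40%, between 20% and 62%. That expectation means a number 37.4 percentage points lower from compound 3 to compound 4 (beyond the scatter).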

Compound 4, a percentage reported as inhibition, at one concentration (the size of the read-out at that concentration, not a potency): 31.3%
For compound 4 the middle estimate is 8.7 percentage points above the measured one; measured number inside the range.
By their numbers in this assay, from the lowest: compounds 2 and 4 (each within the scatter of the next); then compound 1; then compound 3.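

In this assay the change gives a number 46.1 percentage points lower from compound 3 to compound 4 (beyond the scatter) and so shows that pyridin-4-yl at this ring nitrogen also outperforms benzyl, a group whose ring is of carbon only. Benzyl sits level with 4-methylphenyl, with a number 7.3 percentage points higher from compound 2 to compound 4 (within the scatter) and no real difference, but not with 4-methoxyphenyl, with a number 21 percentage points lower from compound 1 to compound 4 (beyond the scatter) as the result. Nothing available explains these differences.

From the compounds shown here alone, whether pyridin-4-ylmethyl would stay close to pyridin-4-yl or fall to the level of benzyl remains open. The same applies to pyridin-3-yl.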